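Swapping a Dichlorophenyl for a Bromophenol on the Hydrazone

This account rests on a few compounds, and the source may have more. Where it says the series, first, only, none or still open, it means among the compounds named here.

Measured so far:
Compound 1, `Cn1c(=O)c(=O)n(C2CCCC2)c2nc(N/N=C/c3cccc(Cl)c3Cl)ncc21`, gives 39100 nM.
Compound 2, `Cn1c(=O)c(=O)n(C2CCCC2)c2nc(N/N=C/c3cc(C(F)(F)F)cc(C(F)(F)F)c3)ncc21`, gives 3230 nM.

Both numbers come from a functional assay on A549 cells (Homo sapiens) for antiproliferative activity, read by MTT assay; on this read-out higher numbers stand for weaker inhibition and lower numbers for stronger inhibition. Compound 1 stands at the higher of the two numbers, so it is the weaker inhibitor of the pair, and its gap to compound 2 lies beyond the usual scatter of this kind of measurement. The two compounds share a core and differ only in the aromatic ring hung on the hydrazone carbon.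

Compound 3, `Cn1c(=O)c(=O)n(C2CCCC2)c2nc(N/N=C/c3ccc(O)c(Br)c3)ncc21`, keeps that core and changes the same ring. Against compound 1 the difference is 3-bromo-4-hydroxyphenyl in place of 2,3-dichlorophenyl on a carbon with a double bond to nitrogen. The new ring carries a hydroxyl group that can donate and accept a hydrogen bond, where the old ring carried none.

For the measured compounds named here, only two numbers exist, and no step between compounds that differ in a single place has been measured, so the direction of this change is not anchored. The step from compound 1 to compound 3 is expected to be small and uncertain, leaning toward a lower number: a 2.0-fold lower number from compound 1 to compound 3 (0.29 log units; within the scatter). Compound 3 is therefore estimated at 20000 nM, within 5000 nM to 80000 nM.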

Compound 3, half-maximal inhibitory concentration: 12800 nM
For compound 3 the middle estimate is 1.6-fold (0.19 log units) above the measured one, within the range that was stated.
By their numbers in this assay, from the lowest: compound 2; then compound 3; then compound 1.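

This position now has a measured step in this assay: putting 3-bromo-4-hydroxyphenyl in place of 2,3-dichlorophenyl gives a 3.1-fold lower number from compound 1 to compound 3 (0.48 log units; beyond the scatter), so the ring on the hydrazone carbon can shift the number while the shared core stays fixed. The entering ring brings a hydrogen-bond donor and acceptor and still lowers the number, yet compound 2, whose ring carries no hydroxyl, has the lowest number of the three at 3230 nM, so a hydroxyl is not required for a lower number here. No measurement is available that explains this step.

The whole ring changes at once in this step, so the compounds shown cannot divide the change among the loss of the two chlorines, the arrival of the bromine and the arrival of the hydroxyl. From the compounds shown here alone, it also remains open how the number would respond to a methoxy group in place of that hydroxyl, or to an amine or a carboxylic acid on the same ring.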